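Dropping the Trifluoromethyl from Compound 2

The compounds below may be only part of what the source reports. "The series", "measured", "known", "first", "only" and "open" are said of these compounds alone.

Of the compounds shown here, three on a shared core have been measured in a functional assay for agonist activity at Free fatty acid receptor 1 (Homo sapiens), read by FLIPR, in the presence of a further agent that is not named here; on this read-out lower numbers stand for an effect already at smaller amounts and higher numbers for an effect only at larger amounts of compound. Compound 1 `O=C1NC(=O)C(Cc2ccccc2Oc2ccccc2)S1` gives 11300 nM in this assay, compound 3 `Cc1cccc(Oc2ccc(CC3SC(=O)NC3=O)cc2)n1` gives 2620 nM, and compound 2 `O=C1NC(=O)C(Cc2ccc(Oc3ccc(Cl)cc3Cl)cc2C(F)(F)F)S1` gives 88 nM. Compound 2 thus carries the lowest number of the three; its gap to compound 3, the nearest, is beyond the usual scatter, and its gap to compound 1, the furthest, is wider still. No pair among these three differs in one place only, so no single step between measured compounds can be read off.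

Compound 4 `O=C1NC(=O)C(Cc2ccc(Oc3ccc(Cl)cc3Cl)cc2)S1` is the still unmeasured partner of compound 2. The change is hydrogen in place of trifluoromethyl on an aromatic carbon, with the 2,4-dichlorophenoxy group kept. Compound 1 and compound 3, which both lack a trifluoromethyl, sit far above compound 2, yet they also differ from it in the other ring. What the trifluoromethyl alone contributes therefore cannot be read from these three compounds. The account therefore expects a moderate rise in the number, beyond the scatter but well short of the values of compound 1 or compound 3.

For compound 4 the expected value in this assay is 400 nM, within a range from 120 nM to 1500 nM. The step this estimate implies is a 4.5-fold higher number from compound 2 to compound 4 (0.66 log units; beyond the scatter).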

Compound 4, half-maximal effective concentration: 101 nM
Compound 4: middle estimate off by 4.0-fold (0.60 log units), on the high side; the measured number lies below the stated range.
By their numbers in this assay, from the lowest: compounds 2 and 4 (each within the scatter of the next); then compound 3; then compound 1.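

In this assay, hydrogen in place of trifluoromethyl on an aromatic carbon gives a 1.1-fold higher number from compound 2 to compound 4 (0.06 log units; within the scatter), the only step shown that isolates a single change. At this position, ortho to the (2,4-dioxo-1,3-thiazolidin-5-yl)methyl group and meta to the 2,4-dichlorophenoxy group, the trifluoromethyl can therefore be exchanged for hydrogen without a change in the number beyond the scatter, as long as the 2,4-dichlorophenoxy group stays in place. The data offer no measurement that would explain this outcome.

As far as these compounds go, only hydrogen and trifluoromethyl have been compared at this position, so the effect of a chlorine atom, a methoxy group or an amine there remains open. It is also open whether the same exchange would give so small a step in compounds without the 2,4-dichlorophenoxy group, such as compound 3, for which no trifluoromethyl partner is shown.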